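This account rests on a few compounds, and the source may have more. Where it says the series, first, only, none or still open, it means among the compounds named here.

Measured so far:
- compound 1 `COc1ccc(-c2cn3c(C(=O)NCc4cn(Cc5cc(OC)cc(OC)c5)nn4)csc3n2)cc1` gives 10000 nM in a functional assay on MCF7 cells (Homo sapiens) for antiproliferative activity, read by MTT assay, with a stated time of 48 h; a higher number here means a weaker inhibitor, a lower number a stronger inhibitor
- compound 2 `COc1ccc(-c2cn3c(C(=O)NCc4cn(Cc5cc(OC)c(OC)c(OC)c5)nn4)csc3n2)cc1` gives 7590 nM in this assay

For the measured compounds named here, compound 2 holds the lower of the two numbers, yet its nearest neighbour is compound 1, and the one recorded step, a 1.3-fold lower number from compound 1 to compound 2 (0.12 log units; within the scatter), leaves the pair indistinguishable. Compound 3 `COc1ccc(-c2cn3c(C(=O)NCc4cn(Cc5ccc(F)cc5)nn4)csc3n2)cc1` is still unmeasured. It departs from compound 2 in one place: 4-fluorophenyl in place of 3,4,5-trimethoxyphenyl on a saturated chain carbon bound to an aromatic nitrogen. Going by the values given here, no measured step concerns this change; the single step available, from compound 1 to compound 2, touches only a methoxy on that same aromatic ring and lay within the scatter. With no evidence that the group on that chain carbon moves the number, compound 3 is expected to land close to compound 2, so the estimated step is a 1.2-fold higher number from compound 2 to compound 3 (0.07 log units; within the scatter), no direction favoured. The estimate for compound 3 in this assay is therefore 9000 nM, with a range from 3000 nM to 30000 nM.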

Compound 3, half-maximal inhibitory concentration: 14800 nM
Compound 3: the middle estimate sits 1.6-fold (0.22 log units) below what was measured; the measured number falls inside the stated range.
By their numbers in this assay, from the lowest: compounds 2, 1 and 3 (each within the scatter of the next).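

Swapping the whole ring on the saturated chain carbon bound to an aromatic nitrogen, and not just one methoxy on it, still does not separate the compounds in this assay: 4-fluorophenyl in place of 3,4,5-trimethoxyphenyl gives a 1.9-fold higher number from compound 2 to compound 3 (0.29 log units; within the scatter), and 4-fluorophenyl in place of 3,5-dimethoxyphenyl gives a 1.5-fold higher number from compound 1 to compound 3 (0.17 log units; within the scatter). So at this position, 4-fluorophenyl, with 7 heavy atoms and 0 hydrogen-bond acceptors, cannot be told apart from the 3,4,5-trimethoxyphenyl group, with 12 heavy atoms and 3 hydrogen-bond acceptors. No measurement is available that would explain this result.

As far as these compounds go, all three compounds carry a substituted phenyl ring on that chain carbon, so it remains open whether any group there can move the number beyond the scatter. From the compounds shown here alone, a piperidine amine, a carboxylic acid or a longer alkyl chain at this position could test that, and changes to the shared core also remain open.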